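Aryl exchange on the saturated ring carbon: lipophilicity notes

This account rests on a few compounds, and the source may have more. Where it says the series, first, only, none or still open, it means among the compounds named here.

Compound 1 `C[C@H]1CC[C@@H]2[C@@H](OC(=O)[C@]23CC(c2ccc(O)cc2)=NO3)[C@]2(C)C(=O)C=C[C@@]12O` — a physicochemical assay for lipophilicity; a lower number here means a more polar compound, a higher number a more lipophilic compound: 0.932
Compound 2 `C[C@H]1CC[C@@H]2[C@@H](OC(=O)[C@]23CC(c2ccc(F)cc2)N(c2ccccc2)O3)[C@]2(C)C(=O)C=C[C@@]12O` — this assay: 3.35

In this assay compound 2 holds the higher of the two numbers; compound 1 sits far lower, beyond the scatter. Among the measured compounds shown here, no pair of measured compounds differs in a single place, so no measured step can be read off. Compound 3 `C[C@H]1CC[C@@H]2[C@@H](OC(=O)[C@]23CC(c2ccccc2Cl)N(c2ccccc2)O3)[C@]2(C)C(=O)C=C[C@@]12O` is not yet measured; it differs from compound 2 by 2-chlorophenyl in place of 4-fluorophenyl on a saturated ring carbon. For this exchange a modest upward step in this assay is expected, likely just beyond the scatter, with the expected step being a number 0.50 log units higher from compound 2 to compound 3 (beyond the scatter). Compound 3 is therefore estimated at 3.85, within a range of 3.4 to 4.3.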

Compound 3, partition coefficient: 3.87
For compound 3 the middle estimate is 0.02 log units below the measured one; the measured number falls inside the stated range.
By their numbers in this assay, from the lowest: compound 1; then compound 2; then compound 3.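

Swapping the aryl group on the saturated ring carbon next to the ring nitrogen gives the first single-place comparison in the series: in this assay, the change is a number 0.52 log units higher from compound 2 to compound 3 (beyond the scatter). This position therefore registers 2-chlorophenyl in place of 4-fluorophenyl, although the heavy-atom count of the group is unchanged. Nothing available accounts for this step.

The compounds shown do not separate the identity of the halogen from its place on the aryl ring, which a 4-chlorophenyl group would address. Going by these compounds, how an aryl group carrying an amine or a carboxylic acid would stand at this carbon also remains open.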